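Working notes: the step from compound 3 to compound 4

The compounds below may be only part of what the source reports. "The series", "measured", "known", "first", "only" and "open" are said of these compounds alone.

The series shares one core, carried by compound 1 `N#Cc1cnc(NCc2cnccc2C(F)(F)F)cc1NC[C@H]1C[C@H](O)C1`, compound 2 `CO[C@H]1CC[C@@H](CNc2cc(NCc3cnccc3C(F)(F)F)ncc2C#N)CC1` and compound 3 `N#Cc1cnc(NCc2cnccc2C(F)(F)F)cc1NC1CCOCC1`, and differs only in the group on a nitrogen on the aromatic ring. In an assay on isolated protein for inhibition of protein kinase C delta type (Homo sapiens), read by TR-FRET, with a stated time of 2 h (a lower number here means a stronger inhibitor, a higher number a weaker inhibitor), compound 1 gives only a limit, > 10000 nM, and not a number (the limit of > 10000 nM in this assay, at which 1 of the 3 values shown sits). In this assay compound 2 gives 5000 nM, and in the same assay compound 3 gives 9800 nM. Compound 3 therefore carries the higher of the two numbers shown, with compound 2 nearest, and the step of a 2.0-fold higher number from compound 2 to compound 3 (0.29 log units; within the scatter) stays within the scatter. The remaining steps, an at least 2.0-fold lower number from compound 1 to compound 2 (0.30 log units; that floor lies within the scatter) and an at least 1.0-fold lower number from compound 1 to compound 3 (0.00 log units; that floor lies within the scatter), start from the limit and are floors only.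

Compound 4 `CC1(C)C[C@H](Nc2cc(NCc3cnccc3C(F)(F)F)ncc2C#N)CC[C@H]1O` differs from compound 3 by 4-hydroxy-3,3-dimethylcyclohexyl in place of oxan-4-yl on a nitrogen on an aromatic ring. The entering group carries a hydroxy, as did the 3-hydroxycyclobutyl of compound 1, and a six-membered ring of carbon only, as did the 4-methoxycyclohexyl of compound 2. Among the measured compounds shown here, none of the measured steps moves beyond the scatter, so no step beyond the scatter is expected in this assay. The expected step of a 1.0-fold higher number from compound 3 to compound 4 (0.01 log units; within the scatter) thus lies within the scatter. Compound 4 is estimated at 10000 nM, with a range from 3000 nM to 30000 nM.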

Compound 4, half-maximal inhibitory concentration: 2200 nM
Compound 4: middle estimate off by 4.5-fold (0.66 log units), on the high side; the measured number lies below the stated range.
By their numbers in this assay, from the lowest: compound 4; then compounds 2 and 3 (each within the scatter of the next). At a limit, above all of these: compound 1.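

In this assay, among the compounds shown here, the change from oxan-4-yl to 4-hydroxy-3,3-dimethylcyclohexyl on the nitrogen gives a 4.5-fold lower number from compound 3 to compound 4 (0.65 log units; beyond the scatter), the first step that has a number at both ends and lies beyond the scatter, so the number does respond to the group at this position. The comparison with the (4-methoxycyclohexyl)methyl group gives a 2.3-fold lower number from compound 2 to compound 4 (0.36 log units; beyond the scatter), so a six-membered ring of carbon only does not by itself set the number, since compound 2 also carries one. The comparison with the (3-hydroxycyclobutyl)methyl group, which also carries a hydroxy, gives an at least 4.5-fold lower number from compound 1 to compound 4 (0.65 log units; beyond the scatter), and this step is only a floor, as compound 1 gives a limit and not a number: the limit of > 10000 nM in this assay, at which 1 of the 4 values shown sits.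

The entering group brings in the hydroxy, the 3,3-dimethyl substitution, the ring of carbon only and the defined stereocentres in a single change, so the compounds shown do not tell which of these carries the step. Also open, from the compounds shown here alone, is whether 4-hydroxycyclohexyl, without the 3,3-dimethyl substitution, or a 4-aminocyclohexyl group, with an amine in place of the hydroxy, would hold the number in this assay.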